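Cytotoxicity at the Assay Ceiling Across a Shared Core

The compounds below may be only part of what the source reports. "The series", "measured", "known", "first", "only" and "open" are said of these compounds alone.

Measured compounds:
compound 1, `COc1cc2nc(SCC(=O)Nc3cccc(S(N)(=O)=O)c3)nc(Nc3c(Cl)cc(/C=C/C#N)cc3Cl)c2cc1OC`: > 194000 nM (a limit of the assay)
compound 2, `COc1cc2nc([S+]([O-])CC(=O)Nc3ccc([N+](=O)[O-])cc3)nc(Nc3c(C)cc(/C=C/C#N)cc3C)c2cc1OC`: 189000 nM
compound 3, `COc1cc2nc([S+]([O-])CC(=O)Nc3ccccc3F)nc(Nc3c(Cl)cc(/C=C/C#N)cc3Cl)c2cc1OC`: > 208000 nM (a limit of the assay)

In an ADME assay on MT4 cells (Homo sapiens) for cytotoxicity, read by MTT assay, with a stated time of 5 days (a higher number here means that more compound is tolerated, a lower number that less compound is tolerated), compound 1 gives > 194000 nM, which is a limit of the assay and not a number. Compound 2 gives 189000 nM in this assay, a real value but one that sits very near the top of the range tested. Compound 3 gives > 208000 nM, again a limit rather than a number. Compound 3 therefore stands at the limit of > 208000 nM in this assay, at which 1 of the 3 values shown sits, and the only other reference point for it is the limit of > 194000 nM in this assay, at which 1 of the 3 values shown sits, at which compound 1 sits. Going by the values given here, no step between measured compounds that differ in a single place is available here, so the three values show only that all of them cluster at or near the ceiling of the assay.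

Compound 4, `COc1cc2nc([S+]([O-])CC(=O)Nc3c(C)cc(C)cc3C)nc(Nc3c(Cl)cc(/C=C/C#N)cc3Cl)c2cc1OC`, differs from compound 3 in one place: 2,4,6-trimethylphenyl in place of 2-fluorophenyl on an amide-type nitrogen. Nothing among the three measured compounds suggests that this change should move the read-out, so the expected step of an at least 1.0-fold lower number from compound 3 to compound 4 (0.01 log units; that floor lies within the scatter) is none beyond the scatter. Compound 4 is therefore expected to give 200000 nM, in a range from 100000 nM to 300000 nM, most likely reported again as a limit.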

Compound 4, half-maximal cytotoxic concentration: 8870 nM
For compound 4 the middle estimate is 23-fold (1.35 log units) above the measured one, outside the stated range (below it).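

In this assay, the group on the amide-type nitrogen proves able to move the read-out: 2,4,6-trimethylphenyl in place of 2-fluorophenyl brings an at least 23-fold lower number from compound 3 to compound 4 (1.37 log units; beyond the scatter), a large step and the only one shown that can be read between compounds differing in one place. Its size is a floor, since compound 3 stands at a limit of the assay and not at a number: the limit of > 208000 nM in this assay, at which 1 of the 4 values shown sits. The three earlier compounds, with no step among them, could not show that cytotoxicity in this assay responds to this group at all, and nothing shown gives a measured property of either group that would account for the change.

The compounds shown leave open whether the drop goes with the methyl groups, with how many there are, or with the loss of the fluorine, and a plain phenyl or a 2-methylphenyl on the same nitrogen would separate these readings. On these data alone, it also remains open whether an amine or a carboxylic acid on that ring would keep the read-out near the top of the range tested.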